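Cytotoxicity of a thiazole amide series in liver cells

The source may report more compounds than this note shows. Statements on the series, on what has been measured and on what is new or still open speak of the compounds shown alone.

Compound 1, `O=C(Nc1ncc(Cc2ccc(F)cc2)s1)C1CCCCC1`: > 50000 nM
Compound 2, `O=C(Nc1ncc(Cc2ccc(Br)cc2)s1)c1ccc2ccccc2c1`: > 50000 nM
Compound 3, `CC(C)(C)C(=O)Nc1ncc(C(Oc2ccc3cc(Br)ccc3c2)c2ccc(Cl)cc2)s1`: "not toxic" (no number reported)

In an ADME assay on HepG2 2.2.15 cells (Homo sapiens) for cytotoxicity (on this read-out higher numbers stand for lower toxicity in this test and lower numbers for higher toxicity in this test), compound 1 gives > 50000 nM, which is a limit of the assay rather than a number. Compound 2 likewise gives > 50000 nM, again a limit and not a measured value. For compound 3 no number is reported at all; its result is given only as "not toxic" (no number reported). Compound 3 therefore stands alongside the two others at the limit of > 50000 nM in this assay, at which 2 of the 3 values shown sit, and nothing in the data sets it apart from them.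

Compound 4, `O=S(=O)(Nc1ncc(C(Oc2ccc3cc(Br)ccc3c2)c2ccc(Cl)cc2)s1)c1cccc2nsnc12`, differs from compound 3 in one place: a group of 12 heavy atoms (6 carbon, 2 nitrogen, 2 oxygen, 2 sulfur; one five-membered aromatic ring with 3 hetero atoms, one six-membered aromatic ring of carbon only) in place of a group of 6 heavy atoms (5 carbon, 1 oxygen; no ring), on a nitrogen on an aromatic ring. Among the measured compounds shown here, no step between two measured compounds is available, so the size of this change in this assay cannot be read from any neighbouring pair. Given that every value so far sits at the limit, compound 4 is expected to stay near that limit as well, with no shift beyond the scatter in either direction. Compound 4 is expected to give about 50000 nM, most likely between 20000 nM and 100000 nM.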

Compound 4, half-maximal cytotoxic concentration: "not toxic" (no number reported)
Compound 4 has no reported number here; no gap can be computed for the estimate.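

In this assay, among the compounds shown here, compound 3 and compound 4 are both reported only as "not toxic", without a number, so no step between them can be read. The compounds shown leave open at what concentration, if any, either compound harms these cells.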